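The source may hold more compounds than are shown below. What is called first, only, known or untested is meant among the compounds shown, and "the series" means these compounds.

Compound 1 `Cc1c(C(=O)N2CCC[C@@H](N)C2)nc(-c2ccc(C#N)c(F)c2)n1-c1ccc2c(cnn2C)c1`: 106 ng.h/mL
Compound 2 `CN[C@H]1CCN(C(=O)c2nc(-c3ccc(C#N)c(F)c3)n(-c3ccc4nn(C)c(Cl)c4c3)c2C)C1`: 640 ng.h/mL
Compound 3 `Cc1c(C(=O)N2CCC[C@@H](N)C2)nc(-c2ccc(C#N)c(F)c2)n1-c1ccc2nn(C)c(Cl)c2c1`: 100 ng.h/mL

These values come from an ADME assay on the whole organism (Mus musculus, strain CD-1) for pharmacokinetics, with a stated time of 6 h, at a dose of 10 mg/kg by the oral route; a lower number here means less compound in the circulation, a higher number more compound in the circulation at the dose given. Compound 3, at 100 ng.h/mL, stands level with compound 1, as a 1.1-fold lower number from compound 1 to compound 3 (0.03 log units; within the scatter) shows. Both carry the 3-aminopiperidin-1-yl group, and compound 2 lies well clear of them, as a 6.4-fold lower number from compound 2 to compound 3 (0.81 log units; beyond the scatter) shows.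

The next compound, compound 4 `CN[C@@H]1CCCN(C(=O)c2nc(-c3ccc(C#N)c(F)c3)n(-c3ccc4nn(C)c(Cl)c4c3)c2C)C1`, differs from compound 3 by one small change: methyl in place of hydrogen on an amine nitrogen. In words, it has methyl in place of hydrogen on an amine nitrogen.

The step between compound 1 and compound 3 concerns a different part of the molecule, so it offers no guide here. Only a 6.4-fold lower number from compound 2 to compound 3 (0.81 log units; beyond the scatter) involves this amine, and it replaces 3-(methylamino)pyrrolidin-1-yl with 3-aminopiperidin-1-yl, so it changes the ring and the methyl together. The data cannot separate those two changes, so only part of that gap can be expected to return when the methyl is added. The expected change is a 2.5-fold higher number from compound 3 to compound 4 (0.40 log units; beyond the scatter), an upward move that is smaller than the gap. The estimated value for compound 4 is 250 ng.h/mL, with an expected range of 90 ng.h/mL to 700 ng.h/mL.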

Compound 4, area under the concentration-time curve: 410 ng.h/mL
Beside the measured number, compound 4's estimate is 1.6-fold (0.21 log units) below it; measured number inside the range.
By their numbers in this assay, from the lowest: compounds 3 and 1 (each within the scatter of the next); then compounds 4 and 2 (each within the scatter of the next).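

Putting methyl in place of hydrogen on the amine nitrogen, with the piperidine ring kept, isolates one of the two changes that were tied together earlier: in this assay it alone gives a 4.1-fold higher number from compound 3 to compound 4 (0.61 log units; beyond the scatter), a clear rise from a single added carbon. Changing only the ring while the methylamino group stays gives a 1.6-fold lower number from compound 2 to compound 4 (0.19 log units; within the scatter), so in this series the methyl, and not the ring, carries the visible difference. Nothing shown here explains why this one methyl matters.

From the compounds shown here alone, it remains open whether a larger group on that nitrogen, such as ethyl, or a second methyl, as in a dimethylamino group, would move the number further. Going by these compounds, it is also open whether the same methyl would give a similar step with the other aromatic group of compound 1.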